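This account rests on a few compounds, and the source may have more. Where it says the series, first, only, none or still open, it means among the compounds named here.

Measured compounds in this study:

- Compound 1, `O=C(/C=C/c1ccc2c(c1)B(O)OC2)c1ccc(F)cc1`, gives in a functional assay on SK-OV-3 cells (Homo sapiens) for cytotoxicity, read by MTT assay, with a stated time of 48 h (a higher number here means a weaker inhibitor, a lower number a stronger inhibitor), a value of 1400 nM.
- Compound 2, `O=C(/C=C/c1ccc2c(c1)B(O)OC2)c1ccc(I)cc1`, gives in this assay a value of 4200 nM.
- Compound 3, `CCc1ccc(C(=O)/C=C/c2ccc3c(c2)B(O)OC3)cc1`, gives in this assay a value of 4400 nM.

Compound 3 has the highest number of the three. Against compound 1 the step is clear: a 3.1-fold higher number from compound 1 to compound 3 (0.50 log units; beyond the scatter). Against compound 2 there is no real gap: a 1.0-fold higher number from compound 2 to compound 3 (0.02 log units; within the scatter). The same pattern holds for the step of a 3.0-fold higher number from compound 1 to compound 2 (0.48 log units; beyond the scatter), so the two larger groups on that aromatic carbon sit together, with fluoro apart from them.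

The next compound, compound 4, `O=C(/C=C/c1ccc2c(c1)B(O)OC2)c1ccc(O)cc1`, changes the same position once more: hydroxy in place of ethyl on an aromatic carbon. Among the measured compounds shown here, no measured step involves a hydroxy, or any group that is a hydrogen-bond donor and acceptor, so the three known steps only set the scale: changes at this carbon have so far shifted the number by modest amounts or not at all. On that basis compound 4 is expected to land near the measured compounds rather than far from them, and the step of a 1.8-fold lower number from compound 3 to compound 4 (0.25 log units; within the scatter) is the expected change. The estimate for compound 4 in this assay is 2500 nM, with a range from 800 nM to 8000 nM.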

Compound 4, half-maximal inhibitory concentration: 13000 nM
For compound 4 the middle estimate is 5.2-fold (0.72 log units) below the measured one, outside the stated range (above it).
By their numbers in this assay, from the lowest: compound 1; then compounds 2 and 3 (each within the scatter of the next); then compound 4.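

Hydroxy is the first group at this aromatic carbon to carry a hydrogen-bond donor and acceptor, and it gives the weakest inhibitor of the four in this assay, with a 3.0-fold higher number from compound 3 to compound 4 (0.47 log units; beyond the scatter) and a 3.1-fold higher number from compound 2 to compound 4 (0.49 log units; beyond the scatter) as its steps from the ethyl and iodo compounds. Among the compounds shown here, the full spread at this one position now reaches a 9.3-fold higher number from compound 1 to compound 4 (0.97 log units; beyond the scatter), wider than any step among the earlier compounds, and size alone does not sort the series: hydroxy has 1 heavy atom against the 2 of ethyl, yet it gives the higher number, so the earlier split of fluoro from the two larger groups does not extend into a simple rule. No measurement shown explains why the number rises with this change.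

On these data alone, what stays open is whether the higher number goes with the oxygen itself or with the hydrogen on it, and a methoxy group at this carbon would separate those two cases. For the compounds shown here, an amine or a carboxylic acid in the same place would show whether other groups of this kind follow hydroxy or fall among the earlier compounds.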